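Cyclohexyl in Place of Hydrogen on an Amine Nitrogen

The source may hold more compounds than are shown below. What is called first, only, known or untested is meant among the compounds shown, and "the series" means these compounds.

Measured so far in a functional assay with Oryctolagus cuniculus as the target; on this read-out lower numbers stand for stronger inhibition and higher numbers for weaker inhibition:
Compound 1 `COc1ccc(-c2nc(N=C(N)N)sc2-c2ccc(OC)cc2)cc1` gives 31000 nM.
Compound 2 `COc1ccc(-c2nc(/N=C(\N)NC(C)C)sc2-c2ccc(OC)cc2)cc1` gives > 100 nM, which is a limit of the assay and not a number.

Compound 1 holds the only plain number shown; the other value is a limit. The step that the limit leaves unreadable from compound 1 to compound 2 cannot be read in size or direction, because compound 2 sits at the limit of > 100 nM in this assay, at which 1 of the 2 values shown sits. Compound 3 `COc1ccc(-c2nc(/N=C(\N)NC3CCCCC3)sc2-c2ccc(OC)cc2)cc1` differs from compound 1 by cyclohexyl in place of hydrogen on an amine nitrogen. Among the measured compounds shown here, the only measured step that bears on this change is the one just named, and it gives no readable size, so no expected size or direction in this assay can be drawn from it. A limit of that kind does not rule out a stronger or a weaker value. With nothing readable to build on, no change beyond the usual scatter is assumed and the range is kept wide. Compound 3 is expected to give about 20000 nM, between 3000 nM and 100000 nM. The estimated step of a 1.6-fold lower number from compound 1 to compound 3 (0.19 log units; within the scatter) is therefore expected to lie near zero.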

Compound 3, half-maximal inhibitory concentration: > 1000 nM
Compound 3 ended at the assay's limit (the forecaster's own chance of this, stated with the estimate: 30%); the middle value does not contradict the limit.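

Among the compounds shown here, compound 2 and compound 3 each give only a limit of the assay, not a number, and no step among compound 1, compound 2 and compound 3 can be read in this assay. The compounds shown leave open whether isopropyl or cyclohexyl on the amine nitrogen gives stronger or weaker inhibition than hydrogen.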